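This account rests on a few compounds, and the source may have more. Where it says the series, first, only, none or still open, it means among the compounds named here.

Measured in a functional assay on MCF7 cells (Homo sapiens) for cytotoxicity, read by WST assay, with a stated time of 72 h; on this read-out lower numbers stand for stronger inhibition and higher numbers for weaker inhibition:
- compound 1 `Cc1ccc(C2(c3ccc(O)cc3)C(=O)Nc3c2ccc(F)c3F)cc1`: 1.7 nM
- compound 2 `CCCCCC1(c2ccc(O)cc2)C(=O)Nc2c1ccc(F)c2F`: 96 nM

Going by the values given here, compound 2 holds the higher of the two numbers, and compound 1 is its only measured neighbour. The next compound, compound 3 `O=C1Nc2c(ccc(F)c2F)C1(Cc1ccccc1)c1ccc(O)cc1`, differs from compound 2 as follows: phenyl in place of butyl on a saturated chain carbon bound to a saturated ring carbon. Cut one bond further out, the same difference reads pentyl to benzyl. Among the compounds with values here, one measured step bears on this change: a 56-fold higher number from compound 1 to compound 2 (1.75 log units; beyond the scatter). That large step replaced 4-methylphenyl with pentyl on a saturated ring carbon. Compound 3 again carries an aromatic ring, but on a saturated chain carbon bound to a saturated ring carbon, so only part of that step is expected to be regained in this assay. A moderate move toward a lower number is therefore expected, and the estimated step is a 4.8-fold lower number from compound 2 to compound 3 (0.68 log units; beyond the scatter). The estimate for compound 3 is 20 nM, with an expected range of 4 nM to 100 nM.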

Compound 3, half-maximal inhibitory concentration: > 1000 nM
Compound 3 was reported as a limit (the forecaster's own chance of this, stated with the estimate: 3%); middle value at least 50-fold (1.69 log units) from the limit.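

In this assay, compound 3 is reported only as a limit and not as a number: the limit of > 1000 nM in this assay, at which 1 of the 3 values shown sits.

An aromatic ring is therefore not enough at this position: the change from 4-methylphenyl to benzyl gives an at least 580-fold higher number from compound 1 to compound 3 (2.76 log units; beyond the scatter). Phenyl in place of butyl on a saturated chain carbon bound to a saturated ring carbon gives an at least 10-fold higher number from compound 2 to compound 3 (1.01 log units; beyond the scatter), so pentyl, which has no ring, keeps the lower number of the two, and the presence of a ring alone does not order these three compounds.

From the compounds shown here alone, because the reading is a limit, the true size of both steps stays open. The compounds shown also leave open how an unsubstituted phenyl, a phenylethyl group or a hexyl chain on the same saturated ring carbon would read.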